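Methoxy on the phenyl ring of a weak compound

The source may hold more compounds than are shown below. What is called first, only, known or untested is meant among the compounds shown, and "the series" means these compounds.

Compound 1 `Nc1ncnn2c([C@@H]3O[C@H](CO)[C@@H](O)[C@H]3O)cc(C#Cc3cccs3)c12`: 50100 nM
Compound 2 `Nc1ncnn2c([C@@H]3O[C@H](CO)[C@@H](O)[C@H]3O)cc(-c3ccccc3)c12`: > 100000 nM

Both compounds were tested in a functional assay on Z-138 cells (Homo sapiens) for antiproliferative activity, with a stated time of 72 h; a higher number here means a weaker inhibitor, a lower number a stronger inhibitor. Compound 2 gives > 100000 nM, which is a limit of the assay and not a number. Compound 3 `COc1ccc(-c2cc([C@@H]3O[C@H](CO)[C@@H](O)[C@H]3O)n3ncnc(N)c23)cc1` turns its phenyl into 4-methoxyphenyl, with methoxy in place of hydrogen on an aromatic carbon. Among the compounds with values here, the only measured step that bears on this is an at least 1.9-fold higher number from compound 1 to compound 2 (0.30 log units; that floor lies within the scatter), and it offers a floor rather than a size. No step beyond the scatter is therefore expected in this assay, and compound 3 is expected to remain weak. The expected step is an at least 1.1-fold lower number from compound 2 to compound 3 (0.04 log units; that floor lies within the scatter). The estimate for compound 3 is 90000 nM, with an expected range of 30000 nM to 200000 nM.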

Compound 3, half-maximal inhibitory concentration: 62600 nM
Beside the measured number, compound 3's estimate is 1.4-fold (0.16 log units) above it, and the stated range covers the measured number.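

In this assay, methoxy in place of hydrogen on the phenyl ring gives an at least 1.5-fold lower number from compound 2 to compound 3 (0.20 log units; that floor lies within the scatter). With 4-methoxyphenyl in place of 2-(thiophen-2-yl)ethynyl there is a 1.2-fold higher number from compound 1 to compound 3 (0.10 log units; within the scatter), so this substituted phenyl reads level with the 2-(thiophen-2-yl)ethynyl group, on a measured number for both. The true size of the methoxy step remains unknown, since the value of compound 2 is a limit of the assay and not a number: the limit of > 100000 nM in this assay, at which 1 of the 3 values shown sits.

On these data alone, it remains open whether an amine, a carboxylic acid or a longer alkoxy chain on that phenyl ring would move the number beyond the scatter.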